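A Second Hydroxy Group Added to Two Different Cores

The source may report more compounds than this note shows. Statements on the series, on what has been measured and on what is new or still open speak of the compounds shown alone.

Compound 2, `COc1cc(/C=N/NC(=O)OCc2ccccc2)ccc1O`, and compound 1, `COc1cc(/C=N/NC(=O)OCc2ccccc2)cc(O)c1O`, share one core and differ at a single spot. In a physicochemical assay, read by spectrophotometry (a lower number here means a stronger inhibitor, a higher number a weaker inhibitor), compound 2 gives 39700 nM. In this assay compound 1 gives 21300 nM. The change between them is hydroxy in place of hydrogen on an aromatic carbon, and the step it made was a 1.9-fold lower number from compound 2 to compound 1 (0.27 log units; within the scatter).

Compound 3, `COc1cc(/C=N/Nc2nc3ccccc3s2)ccc1O`, carries a different core; the difference between the two cores is not broken down here. In this assay compound 3 gives "not determined" (no result reported), so no result was reported for it. Compound 4, `COc1cc(/C=N/Nc2nc3ccccc3s2)cc(O)c1O`, stands to compound 3 as compound 1 stands to compound 2: the change is hydroxy in place of hydrogen on an aromatic carbon. The surroundings of the spot are described in the same words for both pairs, so this is the same change, made on a second core, and it is made on two pairs of compounds in all.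

With no number for compound 3, the step from compound 3 to compound 4 in this assay cannot be anchored at its start. Beside the earlier step of a 1.9-fold lower number from compound 2 to compound 1 (0.27 log units; within the scatter), which lay within the scatter, a step of similar small size is expected here, though this rests only on one pair. Compound 4 is therefore expected to give about 20000 nM in this assay, with the estimate spanning from 5000 nM to 80000 nM.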

Compound 4, half-maximal inhibitory concentration: 6800 nM
Estimate against measurement, compound 4: 2.9-fold (0.47 log units) above, within the range that was stated.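

Among these compounds, compound 3 has no number to set against compound 4 in this assay, so no step between these two compounds can be read. The compounds shown leave open whether hydroxy in place of hydrogen changes the number on this second core by a similar size, by more, or by less than on the first core. No measurement shown here offers an explanation for the value of compound 4.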